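Changing the aryl amide end of a bis-benzylic sulfonamide scaffold

The compounds below may be only part of what the source reports. "The series", "measured", "known", "first", "only" and "open" are said of these compounds alone.

The series is followed through an assay on MDA-MB-231 cells for binding affinity to C-X-C chemokine receptor type 4 (Homo sapiens), read by immunofluorescence and microscopy, with stated times of 10 min and 30 min; a higher number here means that more compound is needed for the effect, a lower number that less compound is needed. Compound 1, `Cc1ccc(S(=O)(=O)NCc2ccc(CNC(=O)c3ccccc3F)cc2)cc1`, gives 1000 nM in this assay, which is the highest of the two numbers recorded. For the measured compounds named here, its nearest neighbour, compound 2, `O=C(NCc1ccc(CNS(=O)(=O)c2ccccc2)cc1)c1ccccc1`, gives 1 nM in this assay, a far lower number; the two structures differ in more than one place, so no single step between them can be laid out, and only the two values themselves can be compared.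

The unmeasured compound 3, `Cc1ccc(S(=O)(=O)NCc2ccc(CNC(=O)c3cccc(C)c3)cc2)cc1`, keeps the core of compound 1 and alters only the aryl amide end: 3-methylphenyl in place of 2-fluorophenyl on a carbonyl carbon. Going by the values given here, no measured pair isolates this kind of change, so the expectation rests on the two values shown, in which the compound whose amide carries an unsubstituted phenyl, compound 2, gives 1 nM.

On that basis compound 3 is expected to move in the direction of a lower number, with a step from compound 1 to compound 3 estimated as a 3.3-fold lower number from compound 1 to compound 3 (0.52 log units; beyond the scatter). For compound 3 the estimated value in this assay is 300 nM, within a range from 30 nM to 3000 nM.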

Compound 3, effective concentration (reported as EC, without a stated level of effect): 1000 nM
Compound 3: the middle estimate sits 3.3-fold (0.52 log units) below what was measured; low and high end bracket the measured number.
By their numbers in this assay, from the lowest: compound 2; then compounds 1 and 3 (each within the scatter of the next).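

In this assay, putting 3-methylphenyl in place of 2-fluorophenyl on a carbonyl carbon gives no change at the digits printed from compound 1 to compound 3 (within the scatter). For the compounds shown here, this is the first single-place step, and it shows that, with the rest of the core of compound 1 held fixed, these two aryl groups of equal heavy-atom count cannot be told apart by this read-out. Nothing measured here bears on why the two groups read alike.

What the compounds shown leave open is what an unsubstituted phenyl on the core of compound 1 would give, and whether a group of another kind at this place, such as an amine or a carboxylic acid on the aryl ring, would move the number at all. Compound 2 gives 1 nM and differs from compound 1 in more than one place, so it remains unknown which of those differences accounts for the gap between their printed values.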